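Naphthyloxyacetyl Hydrazones: From a Chlorophenyl to a Styryl Group

The source may report more compounds than this note shows. Statements on the series, on what has been measured and on what is new or still open speak of the compounds shown alone.

Measured compounds and their values:
compound 1, `O=C(COc1cccc2ccccc12)N/N=C/c1ccccc1[N+](=O)[O-]`, 20 ug/mL;
compound 2, `Cc1ccc(/C=N/NC(=O)COc2cccc3ccccc23)cc1`, 20 ug/mL;
compound 3, `O=C(COc1cccc2ccccc12)N/N=C/c1ccccc1Cl`, 100 ug/mL.

All three share the same core and differ only in the group attached to the carbon that carries a double bond to nitrogen. In an ADME assay on HEL cells (Homo sapiens) for cytotoxicity (on this read-out lower numbers stand for higher toxicity in this test and higher numbers for lower toxicity in this test), compound 3 gives the highest number of the three, so it is the least toxic of them in this test. Two measured steps lead to it. a 5.0-fold higher number from compound 1 to compound 3 (0.70 log units; beyond the scatter) and a 5.0-fold higher number from compound 2 to compound 3 (0.70 log units; beyond the scatter) show that changing this aryl group can move the read-out clearly beyond the scatter, and both changes went in the same direction.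

Compound 4, `O=C(COc1cccc2ccccc12)N/N=C/C=C/c1ccccc1`, has not yet been measured. It differs from compound 3 in one place: 2-phenylethenyl in place of 2-chlorophenyl on a carbon with a double bond to nitrogen. Among the compounds with values here, no measured step swaps an aryl group for a group with a double bond outside an aromatic ring, so the direction must be guessed from the spread of the numbers seen. Since compound 1 and compound 2 both sit well below compound 3, a move back toward them is expected, of roughly a 2.5-fold lower number from compound 3 to compound 4 (0.40 log units; beyond the scatter). Compound 4 is therefore estimated at 40 ug/mL, with a range from 15 ug/mL to 100 ug/mL.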

Compound 4, minimum cytotoxic concentration: 100 ug/mL
Estimate against measurement, compound 4: 2.5-fold (0.40 log units) below; the range from low to high includes it.
By their numbers in this assay, from the lowest: compounds 1 and 2 (each within the scatter of the next); then compounds 3 and 4 (each within the scatter of the next).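

In this assay, putting 2-phenylethenyl in place of 2-chlorophenyl on the carbon with a double bond to nitrogen gives no change at the digits printed from compound 3 to compound 4 (within the scatter) and so leaves the read-out where it was, which shows that this position can take a group with a double bond outside aromatic rings without a clear shift. Measured against 4-methylphenyl, the same group gives a 5.0-fold higher number from compound 2 to compound 4 (0.70 log units; beyond the scatter) and matches the step seen with the chlorinated ring, a 5.0-fold higher number from compound 2 to compound 3 (0.70 log units; beyond the scatter), so among these compounds the higher number, which means lower toxicity in this test, does not depend on having chlorine in this group. Nothing available explains why these groups give the numbers they do.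

Within the data shown here, every group at this position so far carries a six-membered aromatic ring of carbon only, so it remains open how the read-out would respond to a group without such a ring, for example a plain propyl chain, or to a group bearing an amine or a carboxylic acid. On these data alone, it is also open whether a chloro substituent on the ring of the 2-phenylethenyl group would move the number in either direction.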